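Fluoro Enters the Central Ring of Compound 2

This account rests on a few compounds, and the source may have more. Where it says the series, first, only, none or still open, it means among the compounds named here.

Three compounds share one core and differ only in the group on the outer aryl ring. In a functional assay on PC-3 cells (Homo sapiens) for cytotoxicity, read by MTT assay, with a stated time of 72 h (on this read-out higher numbers stand for weaker inhibition and lower numbers for stronger inhibition), compound 1 `O=C(Nc1ccc(Oc2ccnc3[nH]ccc23)cc1)c1cc(-c2ccc(Cl)cc2)ncn1` gives 15600 nM, compound 2 `O=C(Nc1ccc(Oc2ccnc3[nH]ccc23)cc1)c1cc(-c2ccc(C(F)(F)F)cc2)ncn1` gives 2160 nM, and compound 3 `Cc1ccc(-c2cc(C(=O)Nc3ccc(Oc4ccnc5[nH]ccc45)cc3)ncn2)cc1` gives 9880 nM. The step of a 7.2-fold lower number from compound 1 to compound 2 (0.86 log units; beyond the scatter) and the step of a 4.6-fold higher number from compound 2 to compound 3 (0.66 log units; beyond the scatter) both lie beyond the scatter, whereas the step of a 1.6-fold lower number from compound 1 to compound 3 (0.20 log units; within the scatter) does not. Compound 2 therefore holds the lowest number of the three in this assay, with compound 3 nearest and compound 1 furthest.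

Compound 4 `O=C(Nc1ccc(Oc2ccnc3[nH]ccc23)c(F)c1)c1cc(-c2ccc(C(F)(F)F)cc2)ncn1` differs from compound 2 by fluoro in place of hydrogen on an aromatic carbon, on a six-membered aromatic ring of carbon only, ortho to a large group and meta to a large group. Within the data shown here, none of the measured steps bears on this change: each of them swaps the group on the outer aryl ring, and no compound shows what a fluoro on the central ring does. Without such a precedent, the expected step of a 1.1-fold lower number from compound 2 to compound 4 (0.03 log units; within the scatter) is none beyond the scatter. On that basis compound 4 is estimated at 2000 nM in this assay, within a range from 600 nM to 7000 nM.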

Compound 4, half-maximal inhibitory concentration: 4120 nM
Beside the measured number, compound 4's estimate is 2.1-fold (0.31 log units) below it, and the stated range covers the measured number.
By their numbers in this assay, from the lowest: compounds 2 and 4 (each within the scatter of the next); then compounds 3 and 1 (each within the scatter of the next).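

In this assay, fluoro in place of hydrogen on an aromatic carbon, ortho to a large group and meta to a large group, gives a 1.9-fold higher number from compound 2 to compound 4 (0.28 log units; within the scatter), so at this position the change cannot be told apart from the usual scatter of repeated measurements. Among these compounds, the earlier steps all swapped the group on the outer aryl ring, and two of them, a 7.2-fold lower number from compound 1 to compound 2 (0.86 log units; beyond the scatter) and a 4.6-fold higher number from compound 2 to compound 3 (0.66 log units; beyond the scatter), lie beyond the scatter; this step is the first reading from a different place in the shared core, and it shows that this position accepts fluoro with trifluoromethyl kept on the outer ring. Nothing available here accounts for this result.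

The compounds shown leave open whether a larger group at the same position, such as methoxy, an amine or a nitrile, would give a step beyond the scatter. They also leave open whether fluoro at this position would behave the same way with chloro or methyl on the outer ring in place of trifluoromethyl.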